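Cyclopropyl for Bromo on the Core of Compound 3

The compounds below may be only part of what the source reports. "The series", "measured", "known", "first", "only" and "open" are said of these compounds alone.

Of the compounds shown here, three have so far been measured in an assay on HEK293 cells for displacement of a labelled ligand from MAP/microtubule affinity-regulating kinase 3 (Homo sapiens), read by NanoBRET; on this read-out lower numbers stand for stronger inhibition and higher numbers for weaker inhibition. Compound 1 `NS(=O)(=O)c1ccc(CNc2nc(Nc3cccc(NC(=O)N4CCCC4)c3)ncc2Br)cc1` sits at a limit of this assay, giving > 10000 nM. Compound 2 `NS(=O)(=O)c1ccc(CNc2ccnc(Nc3cccc(NC(=O)N4CCCC4)c3)n2)cc1`, which carries hydrogen in place of bromo on an aromatic carbon, also sits at a limit, giving > 10000 nM. The step that the two limits leave unreadable from compound 1 to compound 2 therefore cannot be read. Among the measured compounds shown here, compound 3 `O=C(NCCCNc1nc(Nc2cccc(NC(=O)N3CCCC3)c2)ncc1Br)C1CCC1` is the only compound with a number, giving 137 nM in this assay. For the measured compounds named here, the step of an at least 72-fold lower number from compound 1 to compound 3 (1.86 log units; beyond the scatter) is the one readable change, and it can be stated only as a lower bound because the limit of > 10000 nM in this assay, at which 2 of the 3 values shown sit, holds the starting value.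

Compound 4 `O=C(NCCCNc1nc(Nc2cccc(NC(=O)N3CCCC3)c2)ncc1C1CC1)C1CCC1` differs from compound 3 in a single place: cyclopropyl in place of bromo on an aromatic carbon. Going by the values given here, no measured step touches this group; the readable comparison concerns the chain on the saturated carbon, and the one change at the bromo position is unreadable. Both the bromo that leaves and the cyclopropyl that enters carry no hydrogen-bond donors or acceptors and no charge. The expected step in this assay is a 1.2-fold lower number from compound 3 to compound 4 (0.10 log units; within the scatter), judged to lie within the usual scatter. Compound 4 is accordingly estimated to give 110 nM, with a range from 35 nM to 400 nM.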

Compound 4, half-maximal inhibitory concentration: 2000 nM
For compound 4 the middle estimate is 18-fold (1.26 log units) below the measured one; measured number above the stated range.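

In this assay, among the compounds shown here, cyclopropyl in place of bromo on the aromatic carbon of the shared core gives a 15-fold higher number from compound 3 to compound 4 (1.16 log units; beyond the scatter), the first change at this position whose size can be read, and it is a large one. The read-out therefore depends on which of these two groups the position carries, at least with the chain of compound 3, even though bromo and cyclopropyl both have 0 hydrogen-bond donors, 0 hydrogen-bond acceptors and no net charge, so those counts do not separate the two compounds. The only earlier change at this position, hydrogen in place of bromo, cannot be read, and no size could be attached to it for this reason: the limit of > 10000 nM in this assay, at which 2 of the 4 values shown sit.

The compounds shown leave open what in the change from bromo to cyclopropyl accounts for the step, as the two groups differ in more than one respect and only these two have numbers on this carbon with this chain. Chloro, methyl or a nitrile at the same place on compound 3 would show whether the number follows the size of the group or something particular to bromo.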